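Chloro for fluoro on a shared core

A few compounds are considered here, and "the series" means these few. Any claim that something is new, unique, unknown or untested is made for them only; others in the source may bear on it.

Measured compounds in a functional assay on MDA-MB-435 cells (Homo sapiens) for antiproliferative activity; a higher number here means a weaker inhibitor of growth, a lower number a stronger inhibitor of growth:
compound 1 `Cc1cnc2nc(-c3ccc4ccccc4c3)cc(O)c2c1`: 105 nM.
compound 2 `Cc1cnc2[nH]c(-c3cccc(F)c3)cc(=O)c2c1`: < 10 nM.
compound 3 `Cc1ccc2c(O)cc(-c3cccc(Cl)c3)nc2n1`: < 10 nM.

For compound 2 the value < 10 nM is a limit of this assay, not a number. For compound 3 the value < 10 nM is likewise a limit of this assay. Compound 2 therefore stands at the limit of < 10 nM in this assay, at which 2 of the 3 values shown sit; only compound 1 gives a number, and that number lies well above the limit where compound 2 sits.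

Compound 4 `Cc1cnc2[nH]c(-c3cccc(Cl)c3)cc(=O)c2c1` has not been measured in this assay. It differs from compound 2 by chloro in place of fluoro on an aromatic carbon, with the group on an aromatic carbon of a six-membered aromatic ring of carbon only.

Going by the values given here, no step between measured compounds exists for this change, so nothing measured fixes its size. Compound 3 carries chloro on a different core and also sits at the limit. The step from compound 2 to compound 4 is expected to be none beyond the scatter, a step that the limit leaves unreadable from compound 2 to compound 4, with compound 4 also falling at or under the limit.

Compound 4 is expected at 6 nM in this assay, within the range 2 nM to 18 nM.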

Compound 4, concentration for 50% growth inhibition: < 10 nM
Compound 4: only a limit was reported; the forecaster's own chance of this, stated with the estimate: 65%; the middle value lies beyond the limit too.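

Compound 2 and compound 4 each give only a limit in this assay, so chloro in place of fluoro on an aromatic carbon leaves no readable step between them: the limit of < 10 nM in this assay, at which 3 of the 4 values shown sit. The compounds shown leave open the size of any difference between chloro and fluoro at this place on the shared core.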